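Replacing an allyl thiourea tail with a cyanoguanidine

A few compounds are considered here, and "the series" means these few. Any claim that something is new, unique, unknown or untested is made for them only; others in the source may bear on it.

Compound 1, `O=c1ccc(-c2ccccc2)nn1CCCCNC(=S)NC1CCCCC1`: 18.1%
Compound 2, `C=CCNC(=S)NCCCCn1nc(-c2ccccc2)ccc1=O`: 27.1%

In a functional assay on the whole organism with Rattus norvegicus as the target, at a dose of 100 mg/kg (on this read-out lower numbers stand for less inhibition and higher numbers for more inhibition at the one dose given (going by the name of the read-out)), compound 2 gives the higher of the two numbers, with compound 1 within the scatter of it, as a number 9 percentage points higher from compound 1 to compound 2 (within the scatter) shows. Compound 3, `N#CNC(=N)NCCCn1nc(-c2ccccc2)ccc1=O`, carries a group of 6 heavy atoms (2 carbon, 4 nitrogen; no ring) in place of a group of 8 heavy atoms (5 carbon, 2 nitrogen, 1 sulfur; no ring), on a saturated chain carbon, three bonds along the chain from an aromatic nitrogen. Within the data shown here, no measured step covers this exchange; the one step recorded, at the same tail, was within the scatter. The expectation for compound 3 is therefore a number 5.1 percentage points lower from compound 2 to compound 3 (within the scatter), not clearly beyond the scatter. Compound 3 is estimated at 22% in this assay, between 2% and 45%.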

Compound 3, a percentage reported as inhibition, in the whole organism at one dose (the size of the read-out at that dose, not a potency): 33.3%
Estimate against measurement, compound 3: 11.3 percentage points below; the range from low to high includes it.
By their numbers in this assay, from the lowest: compounds 1, 2 and 3 (each within the scatter of the next, the first and the last beyond it).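

In this assay, the step of a number 6.2 percentage points higher from compound 2 to compound 3 (within the scatter) shows that the whole group on a saturated chain carbon, three bonds along the chain from an aromatic nitrogen, can be exchanged without leaving the scatter. Compound 1 and compound 2 differed only in cyclohexyl against allyl on an amide-type nitrogen, so they left this larger exchange untested. Nothing shown here accounts for the result. Going by these compounds, it remains open whether an amine or a carboxylic acid at this position would move the number beyond the scatter, and what a longer chain would do.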